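Swapping an aryl amide for a homologated arylalkyl amide

A few compounds are considered here, and "the series" means these few. Any claim that something is new, unique, unknown or untested is made for them only; others in the source may bear on it.

Measured compounds:
compound 1 `CC(C)[C@@H](NC(=O)c1cccc(F)c1)C(=O)N1CCC(c2ccc(Cl)cc2)CC1`, 24 nM
compound 2 `CCCC(NC(=O)c1ccccc1C)C(=O)N1CCC(c2ccc(Cl)cc2)CC1`, 152 nM

Both compounds share a piperidine-bearing core and differ in the group attached to the amide carbonyl and in the side chain next to it. In an assay on THP-1 cells for displacement of a labelled ligand from C-C chemokine receptor type 1 (Homo sapiens) (on this read-out higher numbers stand for weaker inhibition and lower numbers for stronger inhibition), compound 1 gives 24 nM, the lower of the two numbers; compound 2 gives 152 nM, and that gap lies beyond the scatter. Because the two compounds differ in more than one place, nothing can be said about which change drives the gap.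

Compound 3 `Cc1ccc(CCC(=O)N[C@@H](C(=O)N2CCC(c3ccc(Cl)cc3)CC2)C(C)C)cc1` is not yet measured. It keeps the side chain and core of compound 1 and alters only the amide: 2-(4-methylphenyl)ethyl in place of 3-fluorophenyl on a carbonyl carbon. For the measured compounds named here, no measured pair isolates this kind of change, so the step from compound 1 to compound 3 has to be guessed. The expectation is a modest loss, expressed as a 3.3-fold higher number from compound 1 to compound 3 (0.52 log units; beyond the scatter), with a wide uncertainty in either direction. Compound 3 is therefore estimated at 80 nM, within a range from 15 nM to 400 nM.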

Compound 3, half-maximal inhibitory concentration: 105 nM
Beside the measured number, compound 3's estimate is 1.3-fold (0.12 log units) below it; low and high end bracket the measured number.
By their numbers in this assay, from the lowest: compound 1; then compounds 3 and 2 (each within the scatter of the next).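

For the compounds shown here, compound 1 and compound 3 share the same side chain and core, so this is the first pair in which the group on the carbonyl carbon can be read on its own: in this assay, placing 2-(4-methylphenyl)ethyl there instead of 3-fluorophenyl gives a 4.4-fold higher number from compound 1 to compound 3 (0.64 log units; beyond the scatter). The group at this place therefore affects the inhibition, although the change is modest and compound 3 still gives a value of 105 nM, even though the entering group has 9 heavy atoms against 7 in the group it replaces and keeps one six-membered aromatic ring of carbon only. Nothing available gives a reason for this step.

Going by these compounds alone, the swap changes several things at once, adding the ethyl link and the methyl and removing the fluorine, so the single step cannot show how much each of these contributes. A benzyl group or an unsubstituted 2-phenylethyl group on the same carbonyl carbon would help separate the effect of chain length from that of the groups on the aromatic ring.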